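Pyrrolidine substituent on a quinolone topoisomerase series

A few compounds are considered here, and "the series" means these few. Any claim that something is new, unique, unknown or untested is made for them only; others in the source may bear on it.

Measured compounds:
- compound 1 `CN[C@@H]1CCN(c2cc3c(cc2F)c(=O)c(C(=O)O)cn3Cc2ccc(-c3ccccc3)cc2)C1`: 34800 nM
- compound 2 `CN[C@@H]1CCN(c2c(F)cc3c(=O)c(C(=O)O)cn(Cc4ccc(-c5ccccc5)cc4)c3c2OC)C1`: 57700 nM
- compound 3 `COc1c(N2CC[C@@H](CN)C2)c(F)cc2c(=O)c(C(=O)O)cn(Cc3ccc4ccccc4c3)c12`: 43700 nM

In an assay on isolated protein for inhibition of DNA topoisomerase 1 (Homo sapiens), with a stated time of 15 min (on this read-out higher numbers stand for weaker inhibition and lower numbers for stronger inhibition), compound 2 gives 57700 nM. Compound 1 and compound 3 both sit within the scatter of that number, so the three measured compounds cannot be ordered against one another. Going by the values given here, the one single-point step among them, a 1.7-fold higher number from compound 1 to compound 2 (0.22 log units; within the scatter), concerns the methoxy on the aromatic carbon and not the group on the pyrrolidine.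

Compound 4 `COc1c(N2CC[C@@H](C(N)=O)C2)c(F)cc2c(=O)c(C(=O)O)cn(Cc3ccc(-c4ccccc4)cc3)c12` differs from compound 2 by carbamoyl in place of methylamino on a saturated ring carbon. Among the compounds with values here, no measured step touches the group on this saturated ring carbon; compound 3 carries a different group there but also differs in the benzyl substituent, so its value shows only that it, too, lies in the same range as compound 2 and compound 1. Within the data shown here, with no step bearing on the change and all measured numbers within scatter of each other, the expected step in this assay is estimated as a 1.0-fold lower number from compound 2 to compound 4 (0.02 log units; within the scatter). Compound 4 is therefore estimated at 55000 nM, with a range from 20000 nM to 150000 nM.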

Compound 4, half-maximal inhibitory concentration: > 200000 nM
Compound 4 gave a limit, no number; the forecaster's own chance of this, stated with the estimate: 20%; at least 3.6-fold (0.56 log units) between middle value and limit.
By their numbers in this assay, from the lowest: compounds 1, 3 and 2 (each within the scatter of the next). At a limit, above all of these: compound 4.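

In this assay compound 4 gives > 200000 nM as its result, which is a limit of the assay and not a number. Going from 3-(methylamino)pyrrolidin-1-yl to 3-carbamoylpyrrolidin-1-yl gives an at least 3.4-fold higher number from compound 2 to compound 4 (0.53 log units; beyond the scatter) and is the first single-place step in the series to lie beyond the scatter, so the group on this saturated ring carbon affects the read-out in a way the methoxy step did not show. The full size of this step remains unknown, since only its lower bound can be read: the limit of > 200000 nM in this assay, at which 1 of the 4 values shown sits.

As far as these compounds go, whether a hydroxyl, a primary amine or a carboxylic acid on this saturated ring carbon would stay in the range of compound 2 remains open. Also open, from the compounds shown here alone, is whether the step carries over to compounds with the different benzyl substituent of compound 3.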